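Ring closure on the amide nitrogen of a two-compound series

The source may report more compounds than this note shows. Statements on the series, on what has been measured and on what is new or still open speak of the compounds shown alone.

Of the compounds shown here, two have been measured in an assay on HEK293T cells for antagonist activity at transient receptor potential cation channel subfamily M member 8 (Homo sapiens), read by fluorescence and calcium flux, with a stated time of 60 min; a lower number here means a stronger inhibitor, a higher number a weaker inhibitor. Compound 1 `C[C@H](c1cc(F)cc(F)c1F)N(C(=O)c1ccccc1)[C@@H](C(N)=O)c1ccccc1` gives 2200 nM, and compound 2 `C[C@H](c1ccccc1)N(C(=O)c1ccccc1)[C@@H](C(N)=O)c1ccccc1` gives 1200 nM. Within the data shown here, the only step between them, a 1.8-fold lower number from compound 1 to compound 2 (0.26 log units; within the scatter), is within the scatter, so compound 2 stands at the lower of two numbers that cannot be told apart. Compound 3 `NC(=O)[C@@H](c1ccccc1)N(C(=O)c1ccccc1)[C@@H]1CCc2ccccc21` differs from compound 2 by 2,3-dihydro-1H-inden-1-yl in place of 1-phenylethyl on an amide-type nitrogen. Among the measured compounds shown here, no measured step touches this part of the molecule: the one step recorded changes the aromatic ring inside the same group, not the group itself, and it was within the scatter. There is therefore no basis for expecting a change in this assay beyond the scatter in either direction. The estimated step, no change at the digits printed from compound 2 to compound 3 (within the scatter), is accordingly small, and compound 3 is expected to give about 1200 nM, with a range from 400 nM to 3600 nM.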

Compound 3, half-maximal inhibitory concentration: 270 nM
Beside the measured number, compound 3's estimate is 4.4-fold (0.65 log units) above it; the measured number lies below the stated range.
By their numbers in this assay, from the lowest: compound 3; then compounds 2 and 1 (each within the scatter of the next).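

In this assay, 2,3-dihydro-1H-inden-1-yl in place of 1-phenylethyl on the amide-type nitrogen gives a 4.4-fold lower number from compound 2 to compound 3 (0.65 log units; beyond the scatter) and so moves the number beyond the scatter. The group on this nitrogen can therefore shift the result as a whole, whereas the change inside the 1-phenylethyl group, phenyl in place of 2,3,5-trifluorophenyl, gave only a 1.8-fold lower number from compound 1 to compound 2 (0.26 log units; within the scatter) and stayed within the scatter. No measurement at hand offers a reason for the new step.

As far as these compounds go, it remains open whether the five-membered ring or simply the added carbon matters, a question an open-chain 1-phenylpropyl group could help to separate. Also open, from the compounds shown here alone, is how a larger ring, such as 1,2,3,4-tetrahydronaphthalen-1-yl, or the opposite stereocentre of the 2,3-dihydro-1H-inden-1-yl group would read.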